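Adding a Methyl Beside the Core of Compound 1

The compounds below may be only part of what the source reports. "The series", "measured", "known", "first", "only" and "open" are said of these compounds alone.

Measured in a functional assay on XF498 cells (Homo sapiens) for inhibition, with a stated time of 72 h; on this read-out lower numbers stand for stronger inhibition and higher numbers for weaker inhibition:
compound 1 (`CC1(c2ccccc2)CC(=O)C(C2CC(c3ccc(-c4ccc(Br)cc4)cc3)Cc3ccccc32)=C(O)O1`) gives 1360 nM.
compound 2 (`COc1ccc(C2Cc3ccccc3C(C3=C(O)OC(C)(c4ccccc4)CC3=O)C2)cc1`) gives > 10000 nM, which is a limit of the assay rather than a number.

Among the compounds with values here, compound 1 therefore holds the only real number here. Compound 2 sits at the limit of > 10000 nM in this assay, at which 1 of the 2 values shown sits. Within the data shown here, the only measured step, an at least 7.3-fold higher number from compound 1 to compound 2 (0.86 log units; beyond the scatter), swaps a group on an aromatic carbon. Compound 3 (`CCC1(c2ccccc2)CC(=O)C(C2CC(c3ccc(-c4ccc(Br)cc4)cc3)Cc3ccccc32)=C(O)O1`) differs from compound 1 at another place: methyl in place of hydrogen on a saturated chain carbon bound to a saturated ring carbon. No measured step touches that place, so nothing shown argues for a change beyond the scatter in this assay. Compound 3 is expected near compound 1, at 1400 nM, between 500 nM and 4000 nM. That expectation means a step of a 1.0-fold higher number from compound 1 to compound 3 (0.01 log units; within the scatter).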

Compound 3, half-maximal inhibitory concentration: > 10000 nM
Compound 3: no number, only a limit; the forecaster's own chance of this, stated with the estimate: 10%; at least 7.1-fold (0.85 log units) between middle value and limit.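

This change shows that the place on a saturated chain carbon bound to a saturated ring carbon also matters: a single methyl in place of hydrogen, turning methyl into ethyl, gives an at least 7.3-fold higher number from compound 1 to compound 3 (0.86 log units; beyond the scatter). Until now, only the swap on an aromatic carbon had moved the number beyond the scatter. The value of compound 3 is a limit of the assay, so the true size of this step stays unknown: the limit of > 10000 nM in this assay, at which 2 of the 3 values shown sit.

The compounds shown leave open whether a propyl chain, a hydroxyl group or an amine at this place would behave like the ethyl of compound 3.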